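Replacing 3,4-dinitrophenyl with 4-hydroxycyclohexyl in compound 4

The compounds below may be only part of what the source reports. "The series", "measured", "known", "first", "only" and "open" are said of these compounds alone.

Values in a functional assay on HeLa cells (Homo sapiens) for inhibition, read by CCK-8 assay, with a stated time of 48 h; a lower number here means a stronger inhibitor, a higher number a weaker inhibitor:
- compound 1 `Cc1cc(C)cc(NC(=O)NCCNS(=O)(=O)c2ccc(-c3ccccc3Oc3ccc([N+](=O)[O-])c([N+](=O)[O-])c3)s2)c1`: 12000 nM
- compound 2 `O=C(NCCNS(=O)(=O)c1ccc(-c2ccccc2O[C@H]2CC[C@H](O)CC2)s1)Nc1ccc([N+](=O)[O-])cc1`: 10500 nM
- compound 3 `O=C(NCCNS(=O)(=O)c1ccc(-c2ccccc2Oc2ccc([N+](=O)[O-])c([N+](=O)[O-])c2)s1)Nc1cc(Cl)cc(Cl)c1`: > 20000 nM (a limit, not a number)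

Compound 3 stands only at a limit: the limit of > 20000 nM in this assay, at which 1 of the 3 values shown sits.

Compound 4 `O=C(NCCNS(=O)(=O)c1ccc(-c2ccccc2O[C@H]2CC[C@H](O)CC2)s1)Nc1cc(Cl)cc(Cl)c1` carries 4-hydroxycyclohexyl in place of 3,4-dinitrophenyl on an oxygen on an aromatic ring.

For the measured compounds named here, no measured step covers this change. Going by the values given here, the only measured step, an at least 1.6-fold higher number from compound 1 to compound 3 (0.22 log units; that floor lies within the scatter), concerns the group on the amide-type nitrogen instead. Compound 2 carries the same 4-hydroxycyclohexyl and gives 10500 nM, which suggests a modest step towards a lower number.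

The expected step is an at least 1.5-fold lower number from compound 3 to compound 4 (0.18 log units; that floor lies within the scatter).

Compound 4 is estimated at 13000 nM, with an expected range of 6000 nM to 26000 nM.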

Compound 4, half-maximal inhibitory concentration: > 20000 nM
Compound 4 ended at the assay's limit; the forecaster's own chance of this, stated with the estimate: 35%; middle value at least 1.5-fold (0.18 log units) away from the limit.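

In this assay compound 4 gives > 20000 nM, which is a limit and not a number. With the 3,5-dichlorophenyl group kept, 4-hydroxycyclohexyl in place of 3,4-dinitrophenyl therefore yields no readable value, and the step between the two compounds cannot be read: the limit of > 20000 nM in this assay, at which 2 of the 4 values shown sit.

With 4-hydroxycyclohexyl kept, 3,5-dichlorophenyl in place of 4-nitrophenyl on an amide-type nitrogen gives an at least 1.9-fold higher number from compound 2 to compound 4 (0.27 log units; that floor lies within the scatter).

On these data alone, whether 4-aminocyclohexyl in place of 4-hydroxycyclohexyl would give a 3,5-dichlorophenyl compound a readable value stays open. As far as these compounds go, how far compound 3 and compound 4 lie past the limit also stays open.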